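A tetrazole where the pyrazoles stood

The compounds below may be only part of what the source reports. "The series", "measured", "known", "first", "only" and "open" are said of these compounds alone.

Three compounds share one core and differ only at a single aromatic carbon. Compound 1 `CC(C)Oc1cc(-c2cncc(-c3cnn(C)c3)c2)ccc1C(N)=O` carries a 1-methyl-1H-pyrazol-4-yl there and gives 400 nM in an assay on cells for inhibition of MAP kinase-interacting serine/threonine-protein kinase 1 (Homo sapiens), read by mobility shift assay, with stated times of 10 min and 60 min, in the presence of a further agent that is not named here; a lower number here means a stronger inhibitor, a higher number a weaker inhibitor. Compound 2 `CC(C)Oc1cc(-c2cncc(-c3c[nH]nc3C3CC3)c2)ccc1C(N)=O` carries a 3-cyclopropyl-1H-pyrazol-4-yl and gives 130 nM. Compound 3 `CC(C)Oc1cc(-c2cccnc2)ccc1C(N)=O` carries only hydrogen at that carbon and gives 880 nM, the highest of the three numbers, which here means the weakest inhibitor of the set.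

Compound 4 `CC(C)Oc1cc(-c2cncc(-c3nn[nH]n3)c2)ccc1C(N)=O` is compound 3 with a change at that same carbon: 2H-tetrazol-5-yl in place of hydrogen on an aromatic carbon. The measured steps that bear on this are the two in which a group at that carbon is removed: a 2.2-fold higher number from compound 1 to compound 3 (0.34 log units; beyond the scatter) and a 6.8-fold higher number from compound 2 to compound 3 (0.83 log units; beyond the scatter). Both show that a five-membered aromatic ring at this position lowers the number, though by differing amounts, as a 3.1-fold lower number from compound 1 to compound 2 (0.49 log units; beyond the scatter) shows. A tetrazole is a five-membered aromatic ring, but with four hetero atoms rather than two, and nothing measured tells how that plays out.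

The expectation for compound 4 is therefore a lower number than compound 3, by a step of about a 2.2-fold lower number from compound 3 to compound 4 (0.34 log units; beyond the scatter). The estimate for compound 4 in this assay is 400 nM, with a range from 150 nM to 1200 nM.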

Compound 4, half-maximal inhibitory concentration: 310 nM
Compound 4: the middle estimate sits 1.3-fold (0.11 log units) above what was measured; low and high end bracket the measured number.
By their numbers in this assay, from the lowest: compound 2; then compounds 4 and 1 (each within the scatter of the next); then compound 3.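

In this assay the 2H-tetrazol-5-yl also beats plain hydrogen at this aromatic carbon, with a 2.8-fold lower number from compound 3 to compound 4 (0.45 log units; beyond the scatter) as its step, so the lowering seen with the two pyrazoles extends to a five-membered aromatic ring with 4 hetero atoms. The new ring falls short of the 3-cyclopropyl-1H-pyrazol-4-yl, with a 2.4-fold higher number from compound 2 to compound 4 (0.38 log units; beyond the scatter) as the gap, yet it cannot be told apart from the 1-methyl-1H-pyrazol-4-yl, with a 1.3-fold lower number from compound 1 to compound 4 (0.11 log units; within the scatter) as the difference, so at this carbon the two rings serve equally well in this measurement despite their different numbers of hetero atoms. No measurement at hand explains why the three rings fall where they do.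

The compounds shown leave open whether a ring is needed here at all, since a carboxylic acid or an amine on this carbon is not among them. Also open, going by these compounds, is what separates compound 2 from compound 1, since the plain 1H-pyrazol-4-yl, carrying neither the methyl nor the cyclopropyl, would be needed to divide the two changes between those compounds.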